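Replacing a methyl with piperidine on compound 3

The source may hold more compounds than are shown below. What is called first, only, known or untested is meant among the compounds shown, and "the series" means these compounds.

In a functional assay on A549 cells (Homo sapiens) for antiproliferative activity, read by MTT assay, with a stated time of 72 h (on this read-out lower numbers stand for stronger inhibition and higher numbers for weaker inhibition), three measured compounds share one core and differ in a single amine group. Compound 1 `CCN(CC)CCCOc1cc2ncnc(Nc3ccc(C#N)cc3)c2cc1OC` gives 50600 nM, and compound 3 `COc1cc2c(Nc3ccc(C#N)cc3)ncnc2cc1OCCCN1CCC(C)CC1` gives 32300 nM. Compound 2 `COc1cc2c(Nc3ccc(C#N)cc3)ncnc2cc1OCCCN(C)Cc1ccccc1` is reported only as a limit of the assay, > 100000 nM.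

Compound 3 therefore stands level with compound 1 within the scatter, as a 1.6-fold lower number from compound 1 to compound 3 (0.19 log units; within the scatter) shows, while an at least 3.0-fold lower number from compound 2 to compound 3 (0.49 log units; beyond the scatter) separates it from compound 2.

Compound 4 `COc1cc2c(Nc3ccc(C#N)cc3)ncnc2cc1OCCCN1CCC(N2CCCCC2)CC1` keeps all of compound 3 except one group: piperidin-1-yl in place of methyl on a saturated ring carbon. Piperidin-1-yl takes the place of methyl on a saturated ring carbon, three ring bonds from the ring nitrogen.

For the measured compounds named here, no measured pair makes this exact change, but all three steps alter the same amine group. Replacing the amine of compound 1 gave an at least 1.9-fold higher number from compound 1 to compound 2 (0.29 log units; that floor lies within the scatter) in one case and a 1.6-fold lower number from compound 1 to compound 3 (0.19 log units; within the scatter) in the other, so these swaps offer no firm direction for compound 4. The expected change is therefore no shift beyond the scatter, estimated as a 1.1-fold lower number from compound 3 to compound 4 (0.03 log units; within the scatter). Compound 2 sits at the limit of > 100000 nM in this assay, at which 1 of the 3 values shown sits, so the expected range stays wide on the high side. For compound 4 the estimated value is 30000 nM, with a range from 10000 nM to 90000 nM.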

Compound 4, half-maximal inhibitory concentration: 30700 nM
The estimate for compound 4 lay 1.0-fold (0.01 log units) below the measured number; low and high end bracket the measured number.
By their numbers in this assay, from the lowest: compounds 4, 3 and 1 (each within the scatter of the next). At a limit, above all of these: compound 2.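

In this assay, piperidin-1-yl in place of methyl, on a saturated ring carbon three ring bonds from the ring nitrogen, gives a 1.1-fold lower number from compound 3 to compound 4 (0.02 log units; within the scatter), so this position takes a whole extra ring with a further nitrogen and the number shows no shift beyond the scatter. Against the two open-chain amines the new group reads as the 4-methylpiperidin-1-yl group did, with a 1.6-fold lower number from compound 1 to compound 4 (0.22 log units; within the scatter) and an at least 3.2-fold lower number from compound 2 to compound 4 (0.51 log units; beyond the scatter), which means the size of the group on this ring carbon has so far not separated the piperidine compounds from each other. Compound 2 is a limit and not a number, so its step gives only a floor: the limit of > 100000 nM in this assay, at which 1 of the 4 values shown sits.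

What remains open is whether a group of another kind on this ring carbon, such as a carboxylic acid, a hydroxyl or a primary amine, would move the number beyond the scatter, since methyl and piperidin-1-yl are the only two shown there. A shorter or longer chain between the oxygen and the amine is also open, as every compound shown carries the same chain.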